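The source may hold more compounds than are shown below. What is called first, only, known or untested is meant among the compounds shown, and "the series" means these compounds.

In a functional assay on MDA-MB-468 cells (Homo sapiens) for antiproliferative activity, read by MTT assay, with a stated time of 72 h (a lower number here means a stronger inhibitor, a higher number a weaker inhibitor), the measured compounds are these
Compound 1 `COc1cc(-c2nccn2-c2ccc3[nH]ccc3c2)cc(OC)c1OC` gives 2300 nM
Compound 2 `COc1ccc(OC(=O)c2cc(OC)c(OC)c(OC)c2)cc1[N+](=O)[O-]` gives > 100000 nM (a limit)

In this assay compound 2 stands at > 100000 nM as a limit of the assay, not a number. Compound 3 `COc1ccc(OC(=O)c2cc(OC)c(OC)c(OC)c2)cc1N` departs from compound 2 at one place, with amino in place of nitro on an aromatic carbon. Among the measured compounds shown here, no measured step covers this change. The expectation in this assay is a sizeable move toward a stronger inhibitor, although another limit remains possible. The expected move is an at least 6.6-fold lower number from compound 2 to compound 3 (0.82 log units; beyond the scatter) in size. Compound 3 is estimated at 15000 nM (expected range 1500 nM to 100000 nM).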

Compound 3, half-maximal inhibitory concentration: > 100000 nM
Compound 3 ended at the assay's limit; the forecaster's own chance of this, stated with the estimate: 35%; middle value at least 6.6-fold (0.82 log units) from the limit.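

In this assay compound 3 gives > 100000 nM, a limit of the assay and not a number. Compound 2 also stands at a limit, and no step can be read between compound 2 and compound 3. The compounds shown leave open whether amino in place of nitro on an aromatic carbon changes the activity at all.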